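A cyclohexyl group replaces vinyl on the chain

The compounds below may be only part of what the source reports. "The series", "measured", "known", "first", "only" and "open" are said of these compounds alone.

Compound 1 `Brc1ccc(Br)c(N(CC2CC2)C2=NCCN2)c1` and compound 2 `C=CCN(C1=NCCN1)c1c(Br)cccc1Br` share a core and differ only in the chain on the nitrogen on the aromatic ring. In a physicochemical assay for acid dissociation, compound 1 gives 11, and compound 2 gives 10.7, the lowest of the two numbers, with the gap to compound 1 lying within the scatter. Compound 3 `Brc1cccc(Br)c1N(CC1CCCCC1)C1=NCCN1` carries cyclohexyl in place of vinyl on a saturated chain carbon bound to a nitrogen on an aromatic ring. Among the compounds with values here, no measured pair shows this step, so only a small step, or none beyond the scatter, is expected: a number 0.20 log units higher from compound 2 to compound 3 (within the scatter). For compound 3 an acid dissociation constant of 10.9 is estimated, with a range from 10.5 to 11.3.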

Compound 3, acid dissociation constant: 11.2
Beside the measured number, compound 3's estimate is 0.30 log units below it, and the stated range covers the measured number.
By their numbers in this assay, from the lowest: compounds 2, 1 and 3 (each within the scatter of the next, the first and the last beyond it).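

In this assay, within the data shown here, the change to cyclohexyl on this saturated chain carbon gives a number 0.50 log units higher from compound 2 to compound 3 (beyond the scatter) and is the first step at this position that stands clear of the scatter. It shows that the chain on the nitrogen can shift the read-out, with the carbon-only six-membered ring going with the higher number. Nothing at hand bears on the origin of this step. Still open, going by these compounds, is whether an open longer chain or a chain carrying an amine would give a similar number. The step rests on this single pair.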